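The source may report more compounds than this note shows. Statements on the series, on what has been measured and on what is new or still open speak of the compounds shown alone.

Measured in a functional assay on Caco-2 cells (Homo sapiens) for cytotoxicity, with a stated time of 48 h; on this read-out higher numbers stand for weaker inhibition and lower numbers for stronger inhibition:
compound 1 `O=[N+]([O-])c1ccc(CN2CCC(n3cc(CC(OCc4cc(-c5ccccc5)no4)c4ccc(Br)cc4)nn3)CC2)cc1` gives 7000 nM
compound 2 `O=[N+]([O-])c1ccc(CN2CCC(n3cc(CC(OCc4cc(-c5ccc(F)cc5)no4)c4ccc(Br)cc4)nn3)CC2)cc1` gives 3000 nM
compound 3 `COc1ccc(-c2cc(COC(Cc3cn(C4CCN(Cc5ccc([N+](=O)[O-])cc5)CC4)nn3)c3ccc(Br)cc3)on2)cc1` gives 3000 nM

Compound 3 stands level with compound 2 at the digits shown, the two together at the low end of the three numbers, while compound 1 is furthest away: a 2.3-fold lower number from compound 1 to compound 3 (0.37 log units; beyond the scatter). Compound 4 `N#Cc1ccc(-c2cc(COC(Cc3cn(C4CCN(Cc5ccc([N+](=O)[O-])cc5)CC4)nn3)c3ccc(Br)cc3)on2)cc1` differs from compound 3 by cyano in place of methoxy on an aromatic carbon. Within the data shown here, no measured step swaps methoxy for cyano. What bears on it are the steps that put a group at that spot of the ring, a 2.3-fold lower number from compound 1 to compound 2 (0.37 log units; beyond the scatter) and a 2.3-fold lower number from compound 1 to compound 3 (0.37 log units; beyond the scatter), both modest and alike in size, and the swap no change at the digits printed from compound 2 to compound 3 (within the scatter), which changed nothing. A further swap there is therefore expected to move little. The estimated step is no change at the digits printed from compound 3 to compound 4 (within the scatter). Compound 4 is expected to give 3000 nM, within 1500 nM to 7000 nM.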

Compound 4, half-maximal inhibitory concentration: 2000 nM
Compound 4: middle estimate off by 1.5-fold (0.18 log units), on the high side; the range from low to high includes it.
By their numbers in this assay, from the lowest: compounds 4, 2 and 3 (each within the scatter of the next); then compound 1.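

Cyano at this spot of the ring behaves like the two groups before it: it stands level with methoxy (a 1.5-fold lower number from compound 3 to compound 4 (0.18 log units; within the scatter)) and with fluoro (a 1.5-fold lower number from compound 2 to compound 4 (0.18 log units; within the scatter)). Against plain hydrogen, it gives a 3.5-fold lower number from compound 1 to compound 4 (0.54 log units; beyond the scatter), so all three listed groups now give lower numbers than compound 1, and no compound shown goes against this. No measurement shown explains why these three groups fall so close together.

Still open, going by these compounds, is whether an amine or a carboxylic acid at this spot would stay level with them. On these data alone, whether hydrogen's gap to these groups would persist on a different core also remains unknown.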